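A Catechol for a Bromophenyl on an Unmeasured Enone

This account rests on a few compounds, and the source may have more. Where it says the series, first, only, none or still open, it means among the compounds named here.

Compound 1, `COc1cccc(/C=C2\CCC/C(=C\c3cc(Cl)cc(Cl)c3)C2=O)c1OC`, in a functional assay on A549 cells (Homo sapiens) for cytotoxicity, read by MTT assay, with a stated time of 72 h (a lower number here means a stronger inhibitor, a higher number a weaker inhibitor), gives 12500 nM.
Compound 2, `COc1cccc(/C=C2\CCC/C(=C\c3ccc(O)c(O)c3)C2=O)c1OC`, in this assay gives > 20000 nM, which is a limit of the assay and not a number.
Compound 3, `COc1ccc(/C=C2\CCC/C(=C\c3ccccc3Br)C2=O)cc1OC`, in this assay gives > 20000 nM, which is a limit of the assay and not a number.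

Compound 3 therefore stands only at a limit; of the three values shown, two sit at that limit (the limit of > 20000 nM in this assay, at which 2 of the 3 values shown sit), and compound 1 alone gives a number. Compound 4, `COc1ccc(/C=C2\CCC/C(=C\c3ccc(O)c(O)c3)C2=O)cc1OC`, is not yet measured. It differs from compound 3 in one place: 3,4-dihydroxyphenyl in place of 2-bromophenyl on a double-bonded chain carbon bound to a double-bonded ring carbon. Among the measured compounds shown here, one measured step bears on this change, where the same group entered in place of 3,5-dichlorophenyl: an at least 1.6-fold higher number from compound 1 to compound 2 (0.20 log units; that floor lies within the scatter). That step ran toward a weaker number, and its floor lies within the scatter, so its true size is not known. Since compound 3 already gives > 20000 nM, a limit, the same change is expected to leave compound 4 at or beyond that limit in this assay. For compound 4 the expected step is a step that the limit leaves unreadable from compound 3 to compound 4. Compound 4 is estimated at 30000 nM, with a range from 15000 nM to 80000 nM.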

Compound 4, half-maximal inhibitory concentration: > 20000 nM
Compound 4 ended at the assay's limit (the forecaster's own chance of this, stated with the estimate: 75%); the middle value lies beyond the limit too.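

In this assay compound 4 gives > 20000 nM, a limit of the assay and not a number. Compound 3 stands at the same limit, so no step can be read between compound 3 and compound 4. The compounds shown leave open whether 3,4-dihydroxyphenyl and 2-bromophenyl differ at all in this assay, with most values resting at one boundary: the limit of > 20000 nM in this assay, at which 3 of the 4 values shown sit.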